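A few compounds are considered here, and "the series" means these few. Any claim that something is new, unique, unknown or untested is made for them only; others in the source may bear on it.

Compound 1 `CCCNc1nc(C)c(-c2nc3ccccc3s2)c(N[C@@H]2C[C@H](CO)[C@@H](O)[C@H]2O)n1`: in an ADME assay on cells (Homo sapiens) for cytotoxicity, read by polymerase chain reaction, with a stated time of 3 days (on this read-out lower numbers stand for higher toxicity in this test and higher numbers for lower toxicity in this test), compound 1 gives > 25000 nM, which is a limit of the assay rather than a number.
Compound 2 `Cc1nc(NCCCC(F)(F)F)nc(N[C@@H]2C[C@H](CO)[C@@H](O)[C@H]2O)c1-c1nc2ccccc2s1`: in this assay compound 2 gives 3000 nM.
Compound 3 `Cc1nc(Nc2ncco2)nc(N[C@@H]2C[C@H](CO)[C@@H](O)[C@H]2O)c1-c1nc2ccccc2s1`: not yet measured.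

Compound 2 thus holds the only number shown; the other value sits at the limit of > 25000 nM in this assay, at which 1 of the 2 values shown sits. For the measured compounds named here, the one measured step, an at least 8.3-fold lower number from compound 1 to compound 2 (0.92 log units; beyond the scatter), shows that changing the chain on this ring nitrogen moved the reading beyond the scatter. Going by the values given here, compound 3 differs from compound 2 by 1,3-oxazol-2-yl in place of 4,4,4-trifluorobutyl on a nitrogen on an aromatic ring, a change no measured step covers, so its direction is open. A modest step back toward the limit is expected, a 3.0-fold higher number from compound 2 to compound 3 (0.48 log units; beyond the scatter). Compound 3 is estimated at 9000 nM, in a range from 2000 nM to 30000 nM.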

Compound 3, half-maximal cytotoxic concentration: > 25000 nM
Compound 3 ended at the assay's limit; the forecaster's own chance of this, stated with the estimate: 35%; middle value at least 2.7-fold (0.44 log units) from the limit.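

Replacing 4,4,4-trifluorobutyl with 1,3-oxazol-2-yl on this nitrogen gives an at least 8.3-fold higher number from compound 2 to compound 3 (0.92 log units; beyond the scatter), so the lower number of compound 2 does not carry over to every group placed here. Among the three compounds, the higher toxicity in this test appears only with the trifluorobutyl chain. The step between compound 1 and compound 3 cannot be read, and only compound 2 carries a number, the other two values being limits: the limit of > 25000 nM in this assay, at which 2 of the 3 values shown sit.

On these data alone, whether a plain butyl chain or a phenyl ring on this nitrogen would read like compound 2 or like compound 3 stays open.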